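Compound 4: a Hydroxyphenyl in Place of a Fluorophenyl

The source may report more compounds than this note shows. Statements on the series, on what has been measured and on what is new or still open speak of the compounds shown alone.

Three compounds share one core and differ only in the aryl group on an aromatic nitrogen. In a functional assay on OVCAR-3 cells (Homo sapiens) for inhibition, read by MTT assay, with a stated time of 24 h (a lower number here means a stronger inhibitor, a higher number a weaker inhibitor), compound 1 `Cc1ccccc1-n1cc(CN2C(=O)C[C@@H]3CC[C@@]2(C)C3(C)C)nn1` gives 150 nM, compound 2 `CC1(C)[C@H]2CC[C@]1(C)N(Cc1cn(-c3cccc(O)c3)nn1)C(=O)C2` gives 370 nM, and compound 3 `CC1(C)[C@H]2CC[C@]1(C)N(Cc1cn(-c3cccc(F)c3)nn1)C(=O)C2` gives 430 nM. Compound 3 thus carries the highest number of the three; it lies within the scatter of compound 2, while the gap to compound 1 is real: a 2.9-fold higher number from compound 1 to compound 3 (0.46 log units; beyond the scatter). Compound 4 `CC1(C)[C@H]2CC[C@]1(C)N(Cc1cn(-c3ccc(O)cc3)nn1)C(=O)C2` carries 4-hydroxyphenyl in place of 3-fluorophenyl on an aromatic nitrogen. Within the data shown here, the one step that bears on this swap is a 1.2-fold higher number from compound 2 to compound 3 (0.07 log units; within the scatter), so exchanging hydroxy for fluoro at the same place changed nothing beyond the scatter; no measured step tests a 4-hydroxyphenyl. The expected step is therefore a 1.1-fold lower number from compound 3 to compound 4 (0.03 log units; within the scatter), small or none. Compound 4 is estimated at 400 nM, with a range from 150 nM to 1100 nM.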

Compound 4, half-maximal inhibitory concentration: 410 nM
Compound 4: the middle estimate sits 1.0-fold (0.01 log units) below what was measured; the range from low to high includes it.
By their numbers in this assay, from the lowest: compound 1; then compounds 2, 4 and 3 (each within the scatter of the next).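

Going from 3-hydroxyphenyl to 4-hydroxyphenyl changes nothing beyond the scatter (a 1.1-fold higher number from compound 2 to compound 4 (0.04 log units; within the scatter)), and the 4-hydroxyphenyl group also stays level with the 3-fluorophenyl group (a 1.0-fold lower number from compound 3 to compound 4 (0.02 log units; within the scatter)). The new compound still falls short of the 2-methylphenyl group, by a modest but real margin (a 2.7-fold higher number from compound 1 to compound 4 (0.44 log units; beyond the scatter)). No measurement offered here explains these numbers.

Open, going by these compounds, is whether the gain in compound 1 comes from the methyl group itself or from where it sits, which 3-methylphenyl and 4-methylphenyl groups could test. Also open, on these data alone, is how an amine or a carboxylic acid on this phenyl ring would behave.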